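A few compounds are considered here, and "the series" means these few. Any claim that something is new, unique, unknown or untested is made for them only; others in the source may bear on it.

Measured compounds:
- compound 1, `CCC(=O)O[C@@H]1CO[C@H]2[C@@H]1OC[C@@H]2OC(=O)c1ccccc1OC(C)=O`: 0.011 h
- compound 2, `COc1ccccc1C(=O)O[C@@H]1CO[C@H]2[C@@H]1OC[C@@H]2OC(=O)c1ccccc1OC(C)=O`: 0.0165 h

Both compounds were examined in an ADME assay on a cell-free system (plasma, Homo sapiens) for metabolic stability, with Plasma (Rattus norvegicus) as the target, read by HPLC, at pH 7.4; on this read-out lower numbers stand for a shorter-lived compound and higher numbers for a longer-lived compound. Compound 1 gives 0.011 h in this assay, and compound 2 gives 0.0165 h. Of the two numbers compound 2 stands highest, but its nearest neighbour is compound 1, and the step of a 1.5-fold higher number from compound 1 to compound 2 (0.18 log units; within the scatter) lies within the scatter, so the two compounds cannot be told apart on these figures.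

Compound 3, `CC(=O)Oc1ccccc1C(=O)O[C@H]1CO[C@H]2[C@@H]1OC[C@H]2OC(=O)c1ccc(-c2ccccc2)cc1`, has not yet been measured in this assay. It differs from compound 2 in one place: 4-phenylphenyl in place of 2-methoxyphenyl on a carbonyl carbon. Within the data shown here, the only measured step that bears on it is the change at the same carbonyl carbon, a 1.5-fold higher number from compound 1 to compound 2 (0.18 log units; within the scatter), which was within the scatter. On that basis no step beyond the scatter is expected for compound 3 in this assay, and a value close to that of compound 2 is estimated, a 1.2-fold higher number from compound 2 to compound 3 (0.08 log units; within the scatter). Compound 3 is therefore expected to give about 0.02 h, with a range from 0.008 h to 0.05 h.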

Compound 3, half-life: > 0.333 h
Compound 3: a limit, no number; the forecaster's own chance of this, stated with the estimate: 10%; middle value at least 16-fold (1.22 log units) away from the limit.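

In this assay compound 3 gives > 0.333 h, which is a limit of the assay and not a number: the limit of > 0.333 h in this assay, at which 1 of the 3 values shown sits. Putting 4-phenylphenyl on this carbonyl carbon gives an at least 20-fold higher number from compound 2 to compound 3 (1.30 log units; beyond the scatter), and set against the ethyl group the same change gives an at least 30-fold higher number from compound 1 to compound 3 (1.48 log units; beyond the scatter). The earlier pair had shown only a 1.5-fold higher number from compound 1 to compound 2 (0.18 log units; within the scatter), so only now is it clear that the group on this carbonyl carbon can shift the half-life beyond the scatter, and that ethyl and 2-methoxyphenyl do not mark the full range of the position.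

Since the value for compound 3 is a limit, the true size of both new steps stays unknown, and the three groups shown cannot say whether the step belongs to the second aromatic ring or to where that ring sits on the first. On these data alone, a plain phenyl group, 3-phenylphenyl or a naphthyl group on the same carbonyl carbon would separate these readings, and whether a group carrying an amine or a carboxylic acid there would behave in the same way remains open.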